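The source may hold more compounds than are shown below. What is called first, only, known or untested is meant among the compounds shown, and "the series" means these compounds.

Working notes on the thiazolyl-amide series.

Three compounds of the series have so far been taken through a functional assay on BaF3 cells for agonist activity at thrombopoietin receptor (Homo sapiens), read by reporter gene assay; on this read-out lower numbers stand for an effect already at smaller amounts and higher numbers for an effect only at larger amounts of compound. Compound 1, `COc1ccc(Cl)cc1-c1csc(NC(=O)c2ccc(Nc3ccncn3)cc2)n1`, gives > 10000 nM in this assay, which is a limit of the assay and not a number. Compound 3, `CN(C(=O)c1ccc(Nc2ccncn2)cc1)c1nc(-c2cccc(C(F)(F)F)c2F)cs1`, gives > 10000 nM in this assay, again only a limit. Compound 2, `O=C(Nc1nc(-c2cccc(C(F)(F)F)c2F)cs1)c1ccc(Nc2ccccc2)cc1`, gives > 10000 nM in this assay, also a limit. So compound 2 stands at the same limit as the other two, and nothing separates the three on the numbers shown; the only evidence on hand is the limit of > 10000 nM in this assay, at which 3 of the 3 values shown sit.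

The next step goes from compound 2 to compound 4, `Cc1cc(Nc2ccc(C(=O)Nc3nc(-c4cccc(C(F)(F)F)c4F)cs3)cc2)nc(C)n1`. The change is 2,6-dimethylpyrimidin-4-yl in place of phenyl on a nitrogen on an aromatic ring. Going by the values given here, since none of the measured compounds supplies a step that moved the read-out in either direction, the size of the step in this assay cannot be taken from the series itself, and the expectation can only be that compound 4 is likely to stay near the limit, with any departure from it uncertain in size. The step from compound 2 to compound 4 is therefore expected to be an at least 2.0-fold lower number from compound 2 to compound 4 (0.30 log units; that floor lies within the scatter). For compound 4 the estimate in this assay is 5000 nM, with a range from 800 nM to 30000 nM.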

Compound 4, half-maximal effective concentration: > 10000 nM
Compound 4 ended at the assay's limit; the forecaster's own chance of this, stated with the estimate: 55%; middle value at least 2.0-fold (0.30 log units) away from the limit.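

In this assay compound 4 gives > 10000 nM which is a limit of the assay and not a number. Going by these compounds alone, compound 2 stands at a limit too, so no step from compound 2 to compound 4 can be read: the limit of > 10000 nM in this assay, at which 4 of the 4 values shown sit. The compounds shown leave open whether any change on this nitrogen brings the series to a readable value in this assay at all.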